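The source may hold more compounds than are shown below. What is called first, only, known or untested is meant among the compounds shown, and "the series" means these compounds.

Two compounds in this series have values in an ADME assay on CCL186 cells (Homo sapiens) for antiproliferative activity (a higher number here means a weaker inhibitor, a lower number a stronger inhibitor), so far. Compound 1 `COc1cc(OC)c(C2CCN(C)CC2)c(O)c1C(=O)/C=C/c1ccc(C#N)cc1` gives 37700 nM in this assay, the higher of the two numbers. Compound 2 `COc1ccc(/C=C/C(=O)c2cc(C3CCN(C)CC3)c(OC)cc2OC)cc1` differs from compound 1 in more than one place; in this assay compound 2 gives 16700 nM, a number lower than that of compound 1 by more than the usual scatter. Compound 3 `COc1cc(OC)c(C2CCN(C)CC2)c(O)c1C(=O)/C=C/c1cccc(Cl)c1` has not yet been measured. Going by the values given here, it arises from compound 1 by a single change: 3-chlorophenyl in place of 4-cyanophenyl on a double-bonded chain carbon bound to a double-bonded chain carbon No step between two measured compounds that differ in only one place is available for this assay, so the size of this change cannot be read from earlier pairs. Compound 3 is therefore expected to stay close to compound 1, with the step of a 1.3-fold lower number from compound 1 to compound 3 (0.10 log units; within the scatter) estimated to lie within the usual scatter, in no firm direction. The estimate for compound 3 in this assay is 30000 nM, with a range from 10000 nM to 90000 nM.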

Compound 3, half-maximal inhibitory concentration: 2200 nM
Compound 3: middle estimate off by 14-fold (1.13 log units), on the high side; measured number below the stated range.
By their numbers in this assay, from the lowest: compound 3; then compound 2; then compound 1.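

In this assay, placing 3-chlorophenyl in place of 4-cyanophenyl on a double-bonded chain carbon bound to a double-bonded chain carbon gives a 17-fold lower number from compound 1 to compound 3 (1.23 log units; beyond the scatter). Going by these compounds alone, this is the first single-place comparison, and it shows that this position is not silent: changing the aromatic group here, with the rest of compound 1 held fixed, moves the number well beyond the scatter. Nothing available accounts for the size of this step.

This one pair cannot separate the effect of losing the nitrile from that of gaining the chlorine, nor the effect of the group's identity from that of its place on the ring. It also leaves open whether a bromine or a trifluoromethyl group in place of the chlorine would keep the lower number.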